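Amide variation on a stilbene-acrylamide core against melanoma cells

A few compounds are considered here, and "the series" means these few. Any claim that something is new, unique, unknown or untested is made for them only; others in the source may bear on it.

Measured so far:
compound 1, `COc1ccc(/C=C/c2cc(OC)cc(OC)c2/C=C/C(=O)N2CCCCC2C)cc1`, 7660 nM
compound 2, `COc1ccc(/C=C/c2cc(OC)cc(OC)c2/C=C/C(=O)N2CCCC2)cc1`, 9280 nM
compound 3, `CCCCCCNC(=O)/C=C/c1c(/C=C/c2ccc(OC)cc2)cc(OC)cc1OC`, 7180 nM

These three compounds share one core and differ only in the group attached to the carbonyl carbon. In a functional assay on B16-F10 cells (Mus musculus) for inhibition, read by MTT assay, with a stated time of 48 h (on this read-out lower numbers stand for stronger inhibition and higher numbers for weaker inhibition), compound 3 gives the lowest of the three numbers, but the two steps that lead to it are a 1.1-fold lower number from compound 1 to compound 3 (0.03 log units; within the scatter) and a 1.3-fold lower number from compound 2 to compound 3 (0.11 log units; within the scatter), so no ordering among the three can be claimed.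

Compound 4, `COc1ccc(/C=C/c2cc(OC)cc(OC)c2/C=C/C(=O)N2CCCC(C)C2)cc1`, is not yet measured. Relative to compound 3 the change is 3-methylpiperidin-1-yl in place of hexylamino on a carbonyl carbon. Within the data shown here, the steps that bear on this are those exchanging the carbonyl substituent: a 1.2-fold higher number from compound 1 to compound 2 (0.08 log units; within the scatter), a 1.1-fold lower number from compound 1 to compound 3 (0.03 log units; within the scatter) and a 1.3-fold lower number from compound 2 to compound 3 (0.11 log units; within the scatter), each within the scatter. The entering group is close to the 2-methylpiperidin-1-yl of compound 1. A step of no more than the scatter is therefore expected, estimated as a 1.1-fold higher number from compound 3 to compound 4 (0.02 log units; within the scatter). For compound 4 the expected value in this assay is 7600 nM, with a range from 4000 nM to 14500 nM.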

Compound 4, half-maximal inhibitory concentration: 8250 nM
The estimate for compound 4 lay 1.1-fold (0.04 log units) below the measured number, within the range that was stated.
By their numbers in this assay, from the lowest: compounds 3, 1, 4 and 2 (each within the scatter of the next).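

Compound 4 puts a ring on the carbonyl carbon in place of an open chain and has no hydrogen-bond donor in that group, whereas hexylamino has one; in this assay this exchange gives a 1.1-fold higher number from compound 3 to compound 4 (0.06 log units; within the scatter) and nothing more. Swapping 2-methylpiperidin-1-yl for 3-methylpiperidin-1-yl gives a 1.1-fold higher number from compound 1 to compound 4 (0.03 log units; within the scatter) and swapping pyrrolidin-1-yl for the same group gives a 1.1-fold lower number from compound 2 to compound 4 (0.05 log units; within the scatter) as well. Across these four compounds, then, neither ring versus chain, nor the donor count, nor the two methyl placements separates the numbers at this position.

No measurement shown explains why the numbers lie so close together. From the compounds shown here alone, whether a different kind of group on the carbonyl carbon, such as morpholin-4-yl or a chain ending in a carboxylic acid or an amine, would move the number beyond the scatter remains open.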